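Methyl to chloro on the aryl ring of compound 2

The compounds below may be only part of what the source reports. "The series", "measured", "known", "first", "only" and "open" are said of these compounds alone.

Measured compounds:
compound 1 `COc1cc(-c2ncnn2-c2cccc(F)c2)cc(OC)c1OC`: > 10000 nM
compound 2 `COc1cc(-n2ncnc2-c2ccc(C)cc2)cc(OC)c1OC`: 90 nM
compound 3 `COc1cc(-c2ncnn2-c2cccc(N)c2)cc(OC)c1OC`: > 10000 nM

For the measured compounds named here, in a functional assay on HL-60 cells (Homo sapiens) for antiproliferative activity, read by MTT assay, with a stated time of 72 h (a lower number here means a stronger inhibitor, a higher number a weaker inhibitor), compound 2 gives 90 nM, the only numerical value among the three measured compounds. Compound 1 reaches only a limit of the assay, > 10000 nM. Compound 3 likewise reaches only a limit, > 10000 nM. Both of these sit at the limit of > 10000 nM in this assay, at which 2 of the 3 values shown sit, so the step that the two limits leave unreadable from compound 1 to compound 3 cannot be read.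

Compound 4 `COc1cc(-n2ncnc2-c2ccc(Cl)cc2)cc(OC)c1OC` is the unmeasured analogue of compound 2; the change is chloro in place of methyl on an aromatic carbon. Going by the values given here, no measured step bears on this change: the one pair that differs in a single place, compound 1 and compound 3, is unreadable and concerns a different group at a different place on a differently arranged core. The expectation therefore rests on compound 2 alone, with no reason to expect a step beyond the scatter in this assay. The expected step of no change at the digits printed from compound 2 to compound 4 (within the scatter) is estimated to lie within the scatter. For compound 4 the estimate is 90 nM, with a range of 30 nM to 300 nM.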

Compound 4, half-maximal inhibitory concentration: > 10000 nM
Compound 4 gave a limit, no number (the forecaster's own chance of this, stated with the estimate: 5%); at least 110-fold (2.04 log units) between middle value and limit.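

In this assay, for the compounds shown here, the change from 4-methylphenyl to 4-chlorophenyl on the core of compound 2 gives an at least 110-fold higher number from compound 2 to compound 4 (2.04 log units; beyond the scatter), the first readable step. Compound 4 gives > 10000 nM, which is a limit of the assay and not a number, so the step has a floor but no upper bound. This single replacement on an aromatic carbon, with one heavy atom leaving and one entering, is enough to take the series from a measured value back to the limit, leaving compound 2 as the only numerical value: the limit of > 10000 nM in this assay, at which 3 of the 4 values shown sit.

The compounds shown do not tell whether methyl is specifically favoured at this place or chloro specifically disfavoured. An ethyl group or a bromo group there would test this, and the data give no reading of what underlies the step.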